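Amine ring variation in a propoxy-linked lactam H1 series

A few compounds are considered here, and "the series" means these few. Any claim that something is new, unique, unknown or untested is made for them only; others in the source may bear on it.

Measured so far:
compound 1, `CN1CCc2ccc(OCCCN3CCCCC3)cc2C1=O`, 23 nM
compound 2, `CC1CCN(CCCOc2ccc3c(c2)C(=O)N(C)CC3)CC1`, 32 nM
compound 3, `CC1CCCN1CCCOc1ccc2c(c1)C(=O)N(C)CC2`, 26 nM

The three compounds share one core and differ only in the saturated amine at the end of the propoxy chain. In an assay on cerebellum for displacement of a labelled ligand from histamine H1 receptor (Cavia porcellus), read by scintillation counting, with a stated time of 60 min (on this read-out lower numbers stand for stronger inhibition and higher numbers for weaker inhibition), compound 3 gives 26 nM, the second highest of the three numbers; its nearest neighbour is compound 1 with a 1.1-fold higher number from compound 1 to compound 3 (0.05 log units; within the scatter), and its furthest is compound 2 with a 1.2-fold lower number from compound 2 to compound 3 (0.09 log units; within the scatter). The remaining pair also shows a 1.4-fold higher number from compound 1 to compound 2 (0.14 log units; within the scatter). Every measured step here is within the scatter, so ring size and a methyl on the ring have not moved this assay.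

Compound 4, `CN1CCN(CCCOc2ccc3c(c2)C(=O)N(C)CC3)CC1`, carries the change (4-methylpiperazin-1-yl in place of 2-methylpyrrolidin-1-yl on a saturated chain carbon, three bonds along the chain from an oxygen on an aromatic ring). For the measured compounds named here, none of the measured steps introduces a second ring nitrogen, so no step bears directly on it; the three amine swaps seen so far only show that the amine ring tolerates small changes. A modest weakening is expected for compound 4, an estimated 2.7-fold higher number from compound 3 to compound 4 (0.43 log units; beyond the scatter). Compound 4 is therefore expected to give about 70 nM, with a range from 20 nM to 250 nM.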

Compound 4, inhibition constant: 706 nM
For compound 4 the middle estimate is 10-fold (1.00 log units) below the measured one; measured number above the stated range.
By their numbers in this assay, from the lowest: compounds 1, 3 and 2 (each within the scatter of the next); then compound 4.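

The amine ring at the end of the propoxy chain is far less tolerant in this assay than the earlier swaps suggested, since the change to 4-methylpiperazin-1-yl gives a 27-fold higher number from compound 3 to compound 4 (1.43 log units; beyond the scatter) and a 31-fold higher number from compound 1 to compound 4 (1.49 log units; beyond the scatter) and also a 22-fold higher number from compound 2 to compound 4 (1.34 log units; beyond the scatter) as large steps, while every step among compound 1, compound 2 and compound 3 lies within the scatter. The last of these steps is the closest comparison: 4-methylpiperidin-1-yl and 4-methylpiperazin-1-yl share a six-membered ring and a methyl, so neither ring size nor the presence of a methyl separates them. No supporting measurement bears on the reason for this loss.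

On these data alone, whether the loss follows the ring nitrogen itself or its methyl remains open; piperazin-1-yl without the methyl, 4-acetylpiperazin-1-yl and morpholin-4-yl would help separate these. As far as these compounds go, whether the step persists with a longer chain also remains open.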